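A few compounds are considered here, and "the series" means these few. Any claim that something is new, unique, unknown or untested is made for them only; others in the source may bear on it.

Measured in a functional assay on EOL1 cells (Homo sapiens) for inhibition, read by fluorescence, with a stated time of 72 h; a higher number here means a weaker inhibitor of growth, a lower number a stronger inhibitor of growth:
compound 1 `CC(C)CCn1cnc2c(Nc3ccc(Cl)cc3)nc(N[C@H]3CC[C@H](N)CC3)nc21`: 90 nM
compound 2 `N[C@H]1CC[C@H](Nc2nc(Nc3ccc(Cl)cc3)c3ncn(C4CCCCC4)c3n2)CC1`: 140 nM

Within the data shown here, compound 1 has the lower of the two numbers, but the only measured step, a 1.6-fold higher number from compound 1 to compound 2 (0.19 log units; within the scatter), does not separate it from compound 2. Compound 3 `CC(C)CCn1cnc2c(NCc3cccc(Cl)c3)nc(N[C@H]3CC[C@H](N)CC3)nc21` differs from compound 1 by 3-chlorobenzyl in place of 4-chlorophenyl on a nitrogen on an aromatic ring. That step changes a different place, so no measurement tests this change, and its size remains uncertain. A moderately higher number is expected in this assay, an expected 3.9-fold higher number from compound 1 to compound 3 (0.59 log units; beyond the scatter). The estimated value for compound 3 is 350 nM, with an expected range of 90 nM to 1400 nM.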

Compound 3, concentration for 50% growth inhibition: 1330 nM
Beside the measured number, compound 3's estimate is 3.8-fold (0.58 log units) below it, within the range that was stated.
By their numbers in this assay, from the lowest: compounds 1 and 2 (each within the scatter of the next); then compound 3.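

In this assay, this position on the nitrogen attached to the aromatic ring responds strongly to the change from (4-chlorophenyl)amino to (3-chlorobenzyl)amino, giving a 15-fold higher number from compound 1 to compound 3 (1.17 log units; beyond the scatter) and so a step beyond the scatter, which the earlier pair did not show. The change alters two things at once, the point of the chlorine and the carbon count of the group, so the step cannot be assigned to either alone. The compounds shown leave open how 4-chlorobenzyl or 3-chlorophenyl would read at this nitrogen. No evidence is available that explains the size of this step.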